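The source may hold more compounds than are shown below. What is called first, only, known or untested is meant among the compounds shown, and "the series" means these compounds.

Measured so far in a functional assay on L1210 cells (Mus musculus) for inhibition; a lower number here means a stronger inhibitor, a higher number a weaker inhibitor:
compound 1 `CCNC(=O)c1ccc2[nH]c(NC(=O)OC)nc2c1`, 10000 nM
compound 2 `COC(=O)Nc1nc2cc(C(=O)OC(C)C)ccc2[nH]1`, 700 nM
compound 3 `COC(=O)Nc1nc2cc(C(=O)OCCC(C)C)ccc2[nH]1`, 10000 nM

Compound 1 gives the same number as compound 3, and the two together stand highest of the three. The only separation in the set is to compound 2, a 14-fold lower number from compound 1 to compound 2 (1.15 log units; beyond the scatter).

Compound 4 `C=CCOC(=O)c1ccc2[nH]c(NC(=O)OC)nc2c1` differs from compound 1 in one place: allyloxy in place of ethylamino on a carbonyl carbon. Two measured steps start from compound 1 and bear on this one, both exchanging the ethylamino for an ester oxygen chain: a 14-fold lower number from compound 1 to compound 2 (1.15 log units; beyond the scatter) and no change at the digits printed from compound 1 to compound 3 (within the scatter). Between the two esters themselves, a 14-fold higher number from compound 2 to compound 3 (1.15 log units; beyond the scatter). So the exchange of ethylamino for an ester gave a large gain with the shorter chain and none with the longer one, and compound 3 goes against any simple rule that esters are better. Allyloxy is nearer to isopropoxy than to isopentyloxy in chain size, so a step toward compound 2 is expected, though a weaker one than a 14-fold lower number from compound 1 to compound 2 (1.15 log units; beyond the scatter), since only one ester of two gained. The expected step is a 5.0-fold lower number from compound 1 to compound 4 (0.70 log units; beyond the scatter).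

Compound 4 is therefore estimated at 2000 nM, with a range of 500 nM to 8000 nM.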

Compound 4, half-maximal inhibitory concentration: > 10000 nM
Compound 4 was reported as a limit; the forecaster's own chance of this, stated with the estimate: 10%; at least 5.0-fold (0.69 log units) between middle value and limit.
By their numbers in this assay, from the lowest: compound 2; then compounds 1 and 3 (each within the scatter of the next).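

In this assay compound 4 stands as a limit and not as a number: the limit of > 10000 nM in this assay, at which 1 of the 4 values shown sits. Against the one ester with a low number, the result is clear: an at least 14-fold higher number from compound 2 to compound 4 (1.15 log units; beyond the scatter), so the exchange of isopropyl for allyl on the oxygen next to the carbonyl group loses what compound 2 had gained, and an ester at this carbonyl carbon with a chain shorter than isopentyl is not enough to keep the gain. Among the three esters shown, compound 2 alone stands apart from the ethylamino amide compound 1. The other two steps are a number no lower from compound 1 to compound 4 (the limit leaves the size open) and a number no lower from compound 3 to compound 4 (the limit leaves the size open), and the size of neither can be read.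

From the compounds shown here alone, what stays open is how far compound 4 lies past the limit, and so whether the allyl ester differs at all from compound 1 or compound 3. Also open, going by these compounds, is how narrowly the low number of compound 2 is tied to isopropyl, which a methyl, ethyl or tert-butyl ester, or the free carboxylic acid, at this carbonyl carbon would address.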